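Methyl on phenyl across two cores: working notes

The compounds below may be only part of what the source reports. "The series", "measured", "known", "first", "only" and "open" are said of these compounds alone.

Measured so far in a functional assay on SK-MEL-28 cells (Homo sapiens) for inhibition, read by colorimetric assay and MTT assay, with a stated time of 72 h; a lower number here means a stronger inhibitor, a higher number a weaker inhibitor:
- compound 1 `COc1cc(C(=O)NNC(=S)Nc2csc(-c3ccccc3)c2)cc(OC)c1OC` gives 55000 nM
- compound 2 `COc1cc(C(=O)NNC(=S)Nc2csc(-c3ccc(C)cc3)c2)cc(OC)c1OC` gives 42000 nM
- compound 3 `Cc1ccc(-c2nnc(Nc3csc(-c4ccccc4)c3)s2)cc1` gives > 100000 nM, which is a limit of this assay and not a number

The change from compound 1 to compound 2 is methyl in place of hydrogen on an aromatic carbon. It moves the value by a 1.3-fold lower number from compound 1 to compound 2 (0.12 log units; within the scatter), so in this assay the methyl leaves the result essentially where it was.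

Compound 3 carries a different core; the difference between the core of compound 1 and the core of compound 3 is not broken down here. For compound 3 only the limit is known, one of the values sitting at the limit of > 100000 nM in this assay, at which 1 of the 3 values shown sits.

Compound 4 `Cc1ccc(-c2cc(Nc3nnc(-c4ccc(C)cc4)s3)cs2)cc1` is not yet measured. It differs from compound 3 by methyl in place of hydrogen on an aromatic carbon, the same change as that from compound 1 to compound 2, at the same kind of place.

For compound 4 the expected step in this assay is a number no higher from compound 3 to compound 4 (the limit leaves the size open), resting on the step of a 1.3-fold lower number from compound 1 to compound 2 (0.12 log units; within the scatter) being within the scatter and on compound 3 sitting at the limit > 100000 nM. The estimate for compound 4 is therefore 100000 nM, with a range from 50000 nM to 300000 nM, and most likely only a limit again.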

Compound 4, half-maximal inhibitory concentration: > 100000 nM
Compound 4: no number, only a limit (the forecaster's own chance of this, stated with the estimate: 75%); the middle value lies on the limit itself.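

In this assay compound 4 gives > 100000 nM, which is a limit and not a number. Compound 3 gives > 100000 nM, again a limit and not a number. For the compounds shown here, no step from compound 3 to compound 4 can be read: the limit of > 100000 nM in this assay, at which 2 of the 4 values shown sit. The compounds shown leave open whether phenyl to 4-methylphenyl changes the result at all on the core of compound 3.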